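The source may hold more compounds than are shown below. What is called first, only, known or untested is meant among the compounds shown, and "the series" means these compounds.

Compounds measured so far:
Compound 1, `CC(C)c1ccc(/C=C/C(=O)c2ccc(OCC(=O)N[C@H]3CCOC3=O)cc2)cc1`: 23400 nM
Compound 2, `Cc1ccc(C(C)C)c(OCCSC(=S)N[C@H]2CCOC2=O)c1`: > 64000 nM
Compound 3, `O=C1OCC[C@@H]1NC(=S)SCCOc1ccccc1`: > 64000 nM

In a functional assay on MCF7 cells (Homo sapiens) for antiproliferative activity, read by MTT assay, with a stated time of 72 h (a lower number here means a stronger inhibitor, a higher number a weaker inhibitor), compound 1 gives 23400 nM, the only actual number among the three results shown. For compound 2 the assay returns only a limit, > 64000 nM, and not a number. For compound 3 the assay likewise returns only a limit, > 64000 nM. Within the data shown here, compound 1 therefore stands alone as the one compound with a measured value, while the other two sit at the limit of > 64000 nM in this assay, at which 2 of the 3 values shown sit. Among the measured compounds shown here, no two measured compounds differ in just one place, so no single step can be read from the numbers.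

Compound 4, `O=C(COc1ccc(C(=O)/C=C/c2ccc(F)c(F)c2)cc1)N[C@H]1CCOC1=O`, has not yet been measured. It differs from compound 1 in one place: 3,4-difluorophenyl in place of 4-isopropylphenyl on a double-bonded chain carbon bound to a double-bonded chain carbon. For the measured compounds named here, with no measured step to lean on, the size of the step in this assay cannot be read from the data; a change no larger than the usual scatter, in either direction, is the plainest expectation. The expected step is a 1.2-fold lower number from compound 1 to compound 4 (0.07 log units; within the scatter). Compound 4 is thus estimated at 20000 nM, with a range from 6000 nM to 64000 nM.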

Compound 4, half-maximal inhibitory concentration: > 64000 nM
Compound 4: no number, only a limit (the forecaster's own chance of this, stated with the estimate: 25%); at least 3.2-fold (0.50 log units) between middle value and limit.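

In this assay, among these compounds, 3,4-difluorophenyl in place of 4-isopropylphenyl on a double-bonded chain carbon bound to a double-bonded chain carbon gives an at least 2.7-fold higher number from compound 1 to compound 4 (0.43 log units; beyond the scatter), the first step in this set that can be read at all, and it shows that this place is not indifferent to the group it carries. From the compounds shown here alone, the step is only a floor, as compound 4 returns a limit and not a number, so the full size of the loss stays unknown. The one change of group is enough to take the shared core from a measured number to the limit, leaving compound 1 as the only compound with an actual value: the limit of > 64000 nM in this assay, at which 3 of the 4 values shown sit.

The compounds shown leave open whether the step reflects the loss of the isopropyl group, the arrival of the two fluorines, or both, as the one change does both at once. Going by these compounds, whether a plain phenyl, a 4-methoxyphenyl or a 4-tert-butylphenyl in this place would stay at the limit or return a number, and how any such number would compare with compound 1, also remains open.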